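The source may report more compounds than this note shows. Statements on the series, on what has been measured and on what is new or still open speak of the compounds shown alone.

Compound 1 `COc1ccc(-c2nc(/N=C(\N)NC(C)C)sc2-c2ccc(OC)cc2)cc1`: 9.1 uM
Compound 2 `COc1ccc(-c2nc(CNC(=O)NC(C)C)sc2-c2ccc(OC)cc2)cc1`: 5.7 uM
Compound 3 `COc1ccc(-c2nc(C(=O)N(C)C)sc2-c2ccc(OC)cc2)cc1`: 3 uM

All three values come from a functional assay (aorta) with Rattus norvegicus as the target; on this read-out higher numbers stand for an effect only at larger amounts of compound and lower numbers for an effect already at smaller amounts. Compound 3 stands at the low end of the series, but its place is only partly resolved. The data show a 3.0-fold lower number from compound 1 to compound 3 (0.48 log units; beyond the scatter), which is a modest separation, while they also show a 1.9-fold lower number from compound 2 to compound 3 (0.28 log units; within the scatter). The remaining pair gives a 1.6-fold lower number from compound 1 to compound 2 (0.20 log units; within the scatter).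

The next compound is compound 4 `CCOC(=O)/C(C#N)=C/c1nc(-c2ccc(OC)cc2)c(-c2ccc(OC)cc2)s1`, still unmeasured. The change is 2-cyano-2-(ethoxycarbonyl)ethenyl in place of dimethylcarbamoyl on an aromatic carbon. All three measured steps bear on it, since each exchanges the group at this same place on the shared core. The largest of them is still modest, so quite different groups here have so far moved the number little. Going by the values given here, no measured compound carries the entering group, however, so the direction is poorly defined. A step within the scatter is expected, leaning slightly towards higher numbers, as compound 3 sits at the low end of the series.

The expected step is a 1.7-fold higher number from compound 3 to compound 4 (0.22 log units; within the scatter). For compound 4 the estimated value is 5 uM, with an expected range from 1.5 uM to 16 uM.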

Compound 4, concentration for half-maximal effect: > 100 uM
Compound 4: only a limit was reported; the forecaster's own chance of this, stated with the estimate: 10%; at least 20-fold (1.30 log units) between middle value and limit.
By their numbers in this assay, from the lowest: compounds 3, 2 and 1 (each within the scatter of the next, the first and the last beyond it). At a limit, above all of these: compound 4.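

In this assay compound 4 gives > 100 uM, which is a limit of the assay and not a number.

Going by these compounds alone, this position is less forgiving than the earlier compounds suggested: replacing the earlier groups with 2-cyano-2-(ethoxycarbonyl)ethenyl gives an at least 33-fold higher number from compound 3 to compound 4 (1.52 log units; beyond the scatter), along with an at least 17-fold higher number from compound 2 to compound 4 (1.24 log units; beyond the scatter) and an at least 10-fold higher number from compound 1 to compound 4 (1.04 log units; beyond the scatter), all large, whereas the three earlier groups span only a modest range. The true size of these steps remains unknown, as compound 4 sits at the limit of the read-out: the limit of > 100 uM in this assay, at which 1 of the 4 values shown sits.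

Going by these compounds, it remains open which part of the entering group goes with the higher number, since the ethenyl link, the nitrile and the ethyl ester arrive together in a single change. A simple ethyl ester, a carboxylic acid or a primary amine at this place on the shared core could help separate these parts and show whether other groups here stay within the modest range of compounds 1, 2 and 3.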